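Aryl replacements on the shared core: compound 3 to compound 4

The compounds below may be only part of what the source reports. "The series", "measured", "known", "first", "only" and "open" are said of these compounds alone.

Of the compounds shown here, three have been measured in a physicochemical assay for lipophilicity; on this read-out higher numbers stand for higher lipophilicity and lower numbers for lower lipophilicity. Compound 1, `O=S(=O)(Nc1nccs1)c1ccc2c(c1)OCC[C@@H]2c1ccc(C(F)(F)F)cc1-c1ccc(F)cc1`, gives 4.5. Compound 2, `O=S(=O)(Nc1nccs1)c1ccc2c(c1)OCC[C@@H]2c1ccc(C(F)(F)F)cc1-c1ccc(F)nc1`, gives 3.2. Compound 3, `O=S(=O)(Nc1nccs1)c1ccc2c(c1)OCC[C@@H]2c1ccc(C(F)(F)F)cc1-c1nccs1`, gives 3.3; it stands second highest of the three numbers, with compound 2 nearest and compound 1 furthest. The measured steps were a number 1.30 log units lower from compound 1 to compound 2 (beyond the scatter) and a number 1.20 log units lower from compound 1 to compound 3 (beyond the scatter), while a number 0.10 log units higher from compound 2 to compound 3 (within the scatter).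

Compound 4, `Cc1nc(-c2cc(C(F)(F)F)ccc2[C@H]2CCOc3cc(S(=O)(=O)Nc4nccs4)ccc32)co1`, is not yet measured. It differs from compound 3 in one place: 2-methyl-1,3-oxazol-4-yl in place of 1,3-thiazol-2-yl on an aromatic carbon. Among the measured compounds shown here, no measured step covers this exact exchange. For the measured compounds named here, the steps that bear on it are the two large ones away from compound 1 and the small one between compound 2 and compound 3, which show that two different heteroaryl groups at this position gave numbers within the scatter of each other. Another five-membered heteroaryl with two hetero atoms is therefore expected to land close to compound 3, with no step beyond the scatter; the estimated step is no change at the digits printed from compound 3 to compound 4 (within the scatter). For compound 4 the estimate in this assay is 3.3, within a range of 2.8 to 3.8.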

Compound 4, distribution coefficient: 2.9
The estimate for compound 4 lay 0.40 log units above the measured number; measured number inside the range.
By their numbers in this assay, from the lowest: compounds 4, 2 and 3 (each within the scatter of the next, the first and the last beyond it); then compound 1.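

In this assay the five-membered heteroaryl groups at this position can be told apart: 2-methyl-1,3-oxazol-4-yl in place of 1,3-thiazol-2-yl gives a number 0.40 log units lower from compound 3 to compound 4 (beyond the scatter), although both groups have the same donor and acceptor counts and no net charge. Among the compounds shown here, the exchange against the six-membered heteroaryl group gives a number 0.30 log units lower from compound 2 to compound 4 (within the scatter), while replacing 4-fluorophenyl gives a number 1.60 log units lower from compound 1 to compound 4 (beyond the scatter), the largest step so far. Nothing on hand accounts for the difference between the two five-membered rings.

The exchange alters the ring hetero atom, the point of attachment and the methyl group together, and these compounds do not separate them. Also open, from the compounds shown here alone, are the position of 1,3-oxazol-4-yl without the methyl group and the effect of an amine or a carboxylic acid on the heteroaryl ring.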